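The source may report more compounds than this note shows. Statements on the series, on what has been measured and on what is new or still open speak of the compounds shown alone.

Compounds measured in a functional assay on HeLa cells (Homo sapiens) for cytotoxicity, read by MTT assay; a lower number here means a stronger inhibitor, a higher number a weaker inhibitor:
- compound 1, `CCCc1nc2c(C)cc(-c3nc4ccccc4n3C)cc2n1S(=O)(=O)c1ccc(OC)cc1`, gives 18300 nM
- compound 2, `CCCc1nc2c(C)cc(-c3nc4ccccc4n3C)cc2n1S(=O)(=O)c1ccc(Cl)cc1`, gives 21400 nM
- compound 3, `CCCc1nc2c(C)cc(-c3nc4ccccc4n3C)cc2n1S(=O)(=O)c1ccc(Br)cc1`, gives 24700 nM

All three share one core and differ only in the group on the sulfonyl sulfur. Compound 3 has the highest number of the three in this assay, yet its distance to the others is small: the step of a 1.3-fold higher number from compound 1 to compound 3 (0.13 log units; within the scatter) and the step of a 1.2-fold higher number from compound 2 to compound 3 (0.06 log units; within the scatter) both lie within the scatter, as does the step of a 1.2-fold higher number from compound 1 to compound 2 (0.07 log units; within the scatter). On these numbers the three compounds cannot be told apart.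

Compound 4, `CCCc1nc2c(C)cc(-c3nc4ccccc4n3C)cc2n1S(=O)(=O)c1ccccc1Cl`, has not yet been measured. It differs from compound 3 in one place: 2-chlorophenyl in place of 4-bromophenyl on a sulfonyl sulfur. The measured steps exchanged methoxy, chloro and bromo within the 4-substituted phenyl, and none of them produced a step beyond the scatter; none of them involves a 2-chlorophenyl, so the effect of that group is not shown by the data. Without a reason to expect a departure, compound 4 is estimated to sit near compound 3 with a step of a 1.1-fold lower number from compound 3 to compound 4 (0.05 log units; within the scatter) in this assay. The estimate for compound 4 is 22000 nM, with a range from 9000 nM to 55000 nM.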

Compound 4, half-maximal inhibitory concentration: > 50000 nM
Compound 4: only a limit was reported; the forecaster's own chance of this, stated with the estimate: 10%; middle value at least 2.2-fold (0.35 log units) from the limit.
By their numbers in this assay, from the lowest: compounds 1, 2 and 3 (each within the scatter of the next). At a limit, above all of these: compound 4.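

In this assay compound 4 is recorded only as a limit of the assay, not as a number: the limit of > 50000 nM in this assay, at which 1 of the 4 values shown sits.

Even so, this position responds to a change of this kind: 2-chlorophenyl in place of 4-chlorophenyl keeps the same atoms and moves only the chlorine, and it gives an at least 2.3-fold higher number from compound 2 to compound 4 (0.36 log units; beyond the scatter), while 2-chlorophenyl in place of 4-methoxyphenyl gives an at least 2.7-fold higher number from compound 1 to compound 4 (0.43 log units; beyond the scatter), both unlike the exchanges among the 4-substituted phenyl groups. The comparison with the bromo compound is less firm, at an at least 2.0-fold higher number from compound 3 to compound 4 (0.30 log units; that floor lies within the scatter), so that pair alone does not separate the two compounds.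

As far as these compounds go, how far the true number of compound 4 lies past its limit stays open. Also open, from the compounds shown here alone, is how a plain methyl on the sulfonyl sulfur, or a phenyl there carrying an amine or a carboxylic acid, would compare.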